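The compounds below may be only part of what the source reports. "The series", "measured", "known", "first", "only" and "open" are said of these compounds alone.

Working notes on the series. In a functional assay for inhibition, with a stated time of 5 min, tested at 1 mM (a lower number here means less inhibition, a higher number more inhibition at the concentration tested (going by the name of the read-out)), compound 2 `COc1ccc(/C(Cl)=C/C=C(\C#N)C(=O)c2c[nH]c3ccccc23)cc1OC` gives 63.6%. For the measured compounds named here, the only other measured member, compound 1 `COc1ccc2[nH]cc(C(=O)/C(C#N)=C/C=C(\Cl)c3ccc(OC)c(OC)c3)c2c1`, gives 58.2% in this assay, and the step of a number 5.4 percentage points higher from compound 1 to compound 2 (within the scatter) leaves the two standing together, with compound 2 neither set apart from nor separated from compound 1 by more than the scatter. Compound 3 `COc1ccc(/C(Cl)=C/C=C(\C#N)C(=O)c2c[nH]c3ccc(Br)cc23)cc1OC` is not yet measured; it differs from compound 2 by bromo in place of hydrogen on an aromatic carbon. Going by the values given here, no measured step involves bromo in place of hydrogen on the core, so nothing among the measured compounds speaks directly to this change. Among the compounds with values here, the single step available, from compound 1 to compound 2, was within the scatter. The expectation for this assay is therefore no step beyond the scatter, a number 0.4 percentage points higher from compound 2 to compound 3 (within the scatter). Compound 3 is estimated at 64% in this assay, with a range from 45% to 80%.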

Compound 3, a percentage reported as inhibition, at one concentration (the size of the read-out at that concentration, not a potency): 80.9%
Beside the measured number, compound 3's estimate is 16.9 percentage points below it; the whole stated range lies below it.
By their numbers in this assay, from the lowest: compounds 1 and 2 (each within the scatter of the next); then compound 3.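

This position, on the six-membered aromatic ring of the fused system, showed no step beyond the scatter when methoxy gave way to hydrogen, but it does respond to bromo: in this assay there is a number 17.3 percentage points higher from compound 2 to compound 3 (beyond the scatter) and, for bromo in place of methoxy, a number 22.7 percentage points higher from compound 1 to compound 3 (beyond the scatter). The group at this position can therefore move the read-out, and among the three groups shown, only bromo stands apart, while hydrogen and methoxy remain within the scatter of each other. Nothing available explains this step.

Whether the step is specific to bromo remains open, as the compounds shown do not include chloro, an amine or a carboxylic acid at this position. On these data alone, each number is also a read-out at a single concentration, so the size of any difference in potency is unknown.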